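This account rests on a few compounds, and the source may have more. Where it says the series, first, only, none or still open, it means among the compounds named here.

The compounds here share one core and were all tested in an ADME assay on Li23 cells (Homo sapiens) for cytotoxicity, read by WST assay; on this read-out higher numbers stand for lower toxicity in this test and lower numbers for higher toxicity in this test. Compound 1 `CCCC(=O)N(C)c1ccc(C(O)(C(F)(F)F)C(F)(F)F)cc1` gives > 100000 nM, which is a limit of the test and not a measured number. Compound 2 `CN(C(=O)c1ccccc1)c1ccc(C(OCCO)(C(F)(F)F)C(F)(F)F)cc1` gives > 20000 nM, again a limit rather than a number. Compound 3 `CN(c1ccc(C(O)(C(F)(F)F)C(F)(F)F)cc1)S(=O)(=O)c1ccccc1Br` is the only one of the three with a definite value, at 9100 nM. Since the other two entries are limits, compound 3 stands as the single measured point in this assay, and no ranking among the three can be drawn from it.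

Compound 4 `COc1ccc(S(=O)(=O)N(C)c2ccc(C(O)(C(F)(F)F)C(F)(F)F)cc2)cc1` differs from compound 3 in a single place: 4-methoxyphenyl in place of 2-bromophenyl on a sulfonyl sulfur. Going by the values given here, no measured pair shows what this change does, so the expectation rests on compound 3 alone. The change is expected to shift the value only modestly, close to the usual scatter, and if anything toward lower toxicity. On that basis compound 4 is estimated to give 15000 nM in this assay, with a range from 6000 nM to 40000 nM. The step this estimate implies is a 1.6-fold higher number from compound 3 to compound 4 (0.22 log units; within the scatter), which is expected to be small.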

Compound 4, half-maximal cytotoxic concentration: 7900 nM
Beside the measured number, compound 4's estimate is 1.9-fold (0.28 log units) above it, and the stated range covers the measured number.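

Going by these compounds alone, this is the first pair here that differs in one place, so it gives the first direct reading of what happens on the sulfonyl sulfur in this assay. Putting 4-methoxyphenyl in place of 2-bromophenyl there gives a 1.2-fold lower number from compound 3 to compound 4 (0.06 log units; within the scatter), so the two compounds cannot be told apart in this test, even though the entering group counts a hydrogen-bond acceptor and the leaving group counts none. Nothing in the data shown explains why these two groups read alike.

Going by these compounds, both groups are substituted phenyl rings, so it stays open whether a group of another kind on the sulfonyl sulfur, such as a plain methyl, a longer alkyl chain, or a phenyl ring carrying an amine or a carboxylic acid, would move the number beyond the usual scatter. A single pair also cannot show whether 2-bromophenyl and 4-methoxyphenyl would stay this close to each other if the rest of the molecule were changed.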